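A few compounds are considered here, and "the series" means these few. Any claim that something is new, unique, unknown or untested is made for them only; others in the source may bear on it.

Compound 1, `COc1cc(OC)c(C(=O)/C=C/c2ccccc2SC)c(OC)c1`, is the starting point of this account. In a functional assay on MDA-MB-231 cells (Homo sapiens), read by fluorescence and BrdU incorporation, with a stated time of 48 h, tested at 25 uM (a lower number here means a stronger effect, a higher number a weaker effect of the compound at the concentration tested), compound 1 gives 16%, the highest of the three numbers recorded, though each of its companions lies within the scatter of it. Compound 2, `COc1cccc(/C=C/C(=O)c2c(OC)cc(OC)cc2OC)c1`, gives 12% in this assay, and compound 3, `COc1cc(OC)c(C(=O)/C=C/c2ccc(F)cc2)c(OC)c1`, gives 10%. The step from compound 1 to compound 2 is a number 4 percentage points lower from compound 1 to compound 2 (within the scatter), and that from compound 1 to compound 3 is a number 6 percentage points lower from compound 1 to compound 3 (within the scatter); between compound 2 and compound 3 the step is a number 2 percentage points lower from compound 2 to compound 3 (within the scatter). None of these rises above the scatter.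

Compound 4, `COc1cc(OC)c(C(=O)/C=C/c2ccc(Br)cc2)c(OC)c1`, has not yet been measured in this assay. Its change from compound 1 is 4-bromophenyl in place of 2-(methylsulfanyl)phenyl on a double-bonded chain carbon bound to a double-bonded chain carbon. The two earlier steps from compound 1 both exchange the 2-(methylsulfanyl)phenyl for another substituted phenyl on the same chain carbon, and both stay within the scatter, the closer parallel being the 4-fluorophenyl of compound 3. On that basis the expected step is a number 4 percentage points lower from compound 1 to compound 4 (within the scatter), that is, nothing beyond the scatter in either direction. Compound 4 is therefore estimated at 12%, within a range of 3% to 25%.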

Compound 4, a percentage reported as activity, at one concentration (the size of the read-out at that concentration, not a potency): 44%
Estimate against measurement, compound 4: 32 percentage points below; the whole stated range lies below it.
By their numbers in this assay, from the lowest: compounds 3, 2 and 1 (each within the scatter of the next); then compound 4.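

At this chain carbon, exchanging one substituted phenyl for another is not always neutral: in this assay the 4-bromophenyl gives a number 28 percentage points higher from compound 1 to compound 4 (beyond the scatter) and a number 32 percentage points higher from compound 2 to compound 4 (beyond the scatter), although the earlier exchanges at the same place stayed within the scatter. The sharpest contrast comes from a single change on an aromatic carbon, bromo in place of fluoro, which gives a number 34 percentage points higher from compound 3 to compound 4 (beyond the scatter) and shows that, within this pair, the identity of the halogen matters for the size of the effect at the concentration tested, something compound 1, compound 2 and compound 3 could not show among themselves. Nothing available here accounts for this weaker effect of compound 4.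

The compounds shown leave open whether this loss of effect is particular to bromo or would also appear with a 4-chlorophenyl or a 4-iodophenyl on the same chain carbon. They also leave open how a phenyl carrying an amine or a carboxylic acid at that place would read in this assay, and whether the bromo result depends on where bromine sits on the ring.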